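Aryl triazole ureas: para substituent swap on the aryl ring

The source may report more compounds than this note shows. Statements on the series, on what has been measured and on what is new or still open speak of the compounds shown alone.

Measured so far:
compound 1 `Cc1ccccc1-n1cc(COc2cccc(NC(=O)Nc3ccc(Cl)c(C(F)(F)F)c3)c2)nn1` gives 3440 nM
compound 2 `CCc1cccc(-n2cc(COc3cccc(NC(=O)Nc4ccc(Cl)c(C(F)(F)F)c4)c3)nn2)c1` gives 37900 nM
compound 3 `CC(C)c1ccc(-n2cc(COc3cccc(NC(=O)Nc4ccc(Cl)c(C(F)(F)F)c4)c3)nn2)cc1` gives 2470 nM

All three were tested in a functional assay on HepG2 cells (Homo sapiens) for inhibition, read by MTT assay, with a stated time of 72 h; on this read-out higher numbers stand for weaker inhibition and lower numbers for stronger inhibition. Compound 3 gives the lowest number of the three, though its gap to compound 1 is within the scatter; only compound 2 lies clearly apart, as a 15-fold lower number from compound 2 to compound 3 (1.19 log units; beyond the scatter) shows. The other steps are an 11-fold higher number from compound 1 to compound 2 (1.04 log units; beyond the scatter) and a 1.4-fold lower number from compound 1 to compound 3 (0.14 log units; within the scatter).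

Compound 4 `O=C(Nc1cccc(OCc2cn(-c3ccc(C(F)(F)F)cc3)nn2)c1)Nc1ccc(Cl)c(C(F)(F)F)c1` differs from compound 3 by trifluoromethyl in place of isopropyl on an aromatic carbon. Within the data shown here, no measured step changes the substituent at this same place; the measured steps move the group around the ring, and the para-substituted compound 3 sits at the low end. Keeping a group para, a step of about a 1.2-fold higher number from compound 3 to compound 4 (0.08 log units; within the scatter) is expected, within the scatter. Compound 4 is estimated at 3000 nM, range 1000 nM to 9000 nM.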

Compound 4, half-maximal inhibitory concentration: 1800 nM
Compound 4: middle estimate off by 1.7-fold (0.22 log units), on the high side, and the stated range covers the measured number.
By their numbers in this assay, from the lowest: compounds 4, 3 and 1 (each within the scatter of the next); then compound 2.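

In this assay the step of a 1.4-fold lower number from compound 3 to compound 4 (0.14 log units; within the scatter) shows that trifluoromethyl and isopropyl on this aromatic carbon cannot be told apart. With a 1.9-fold lower number from compound 1 to compound 4 (0.28 log units; within the scatter) also within the scatter and a 21-fold lower number from compound 2 to compound 4 (1.32 log units; beyond the scatter) beyond it, compound 2 alone stands apart from the other three. Nothing available explains these results.
From the compounds shown here alone, whether an amine, a methoxy group or a carboxylic acid on this aromatic carbon would keep the number at this level stays open. So does whether trifluoromethyl placed elsewhere on this ring would repeat the gap seen for compound 2.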